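Aryl swap on the ring nitrogen: compound 3 to compound 4

The compounds below may be only part of what the source reports. "The series", "measured", "known", "first", "only" and "open" are said of these compounds alone.

Three compounds share one core and differ only in the aryl group on the aromatic nitrogen. In a functional assay on PC-12 cells (Rattus norvegicus) for cytotoxicity, read by MTT assay, with stated times of 2 h and 24 h, tested at 5 uM (on this read-out lower numbers stand for a weaker effect and higher numbers for a stronger effect at the one concentration tested), compound 1 `Oc1cc(C(F)(F)F)ccc1-c1nc(-c2ccccc2O)n(-c2ccc(Cl)cc2)n1` gives 87.3%. Compound 2 `COc1ccc(-n2nc(-c3ccc(C(F)(F)F)cc3O)nc2-c2ccccc2O)cc1` gives 86.6% in this assay, and compound 3 `Oc1cc(C(F)(F)F)ccc1-c1nc(-c2ccccc2O)n(-c2ccc(OC(F)(F)F)cc2)n1` gives 84.9% in this assay. The measured steps are all small: a number 0.7 percentage points lower from compound 1 to compound 2 (within the scatter), a number 2.4 percentage points lower from compound 1 to compound 3 (within the scatter) and a number 1.7 percentage points lower from compound 2 to compound 3 (within the scatter). Compound 3 thus holds the lowest of the three numbers, but its gaps to compound 2 and to compound 1 both lie within the scatter, so no order among the three can be read.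

Compound 4 `Oc1cc(C(F)(F)F)ccc1-c1nc(-c2ccccc2O)n(-c2cccc(C(F)(F)F)c2)n1` has not been measured. Its difference from compound 3 is 3-(trifluoromethyl)phenyl in place of 4-(trifluoromethoxy)phenyl on an aromatic nitrogen. All three measured steps concern the same place, the aryl group on the aromatic nitrogen, and none of them moved the read-out of this assay beyond the scatter. On that basis no step beyond the scatter is expected for compound 4 either, in either direction. Compound 4 is therefore estimated at 85.5% in this assay, with a range from 76% to 93%. The expected step is a number 0.6 percentage points higher from compound 3 to compound 4 (within the scatter).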

Compound 4, a percentage reported as activity, at one concentration (the size of the read-out at that concentration, not a potency): 92.2%
Estimate against measurement, compound 4: 6.7 percentage points below, and the stated range covers the measured number.
By their numbers in this assay, from the lowest: compounds 3, 2, 1 and 4 (each within the scatter of the next).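

Among the groups on the aromatic nitrogen, 3-(trifluoromethyl)phenyl differs from 4-chlorophenyl, 4-methoxyphenyl and 4-(trifluoromethoxy)phenyl in both the substituent and its place on the phenyl ring. Even this double change stays within the scatter, with a number 7.3 percentage points higher from compound 3 to compound 4 (within the scatter) and a number 5.6 percentage points higher from compound 2 to compound 4 (within the scatter) and a number 4.9 percentage points higher from compound 1 to compound 4 (within the scatter) in this assay as the read-out, so the four aryl groups shown cannot be ranked and the substituent and its place cannot be told apart. No evidence on what lies behind these numbers is available for the series.

The compounds shown leave open whether any aryl group on this nitrogen can move the read-out beyond the scatter, for instance a phenyl bearing an amine or a carboxylic acid, or a longer alkyl chain in place of the aryl group. With one concentration per compound, they also leave open how the four compare in potency, and whether the two hydroxyl groups and the trifluoromethyl group on the shared core matter to the read-out.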